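The compounds below may be only part of what the source reports. "The series", "measured", "known", "first", "only" and "open" are said of these compounds alone.

Of the compounds shown here, three built on one shared core have been measured in a functional assay on HEK293 cells for agonist activity at D(4) dopamine receptor (Homo sapiens), read by FLIPR; a lower number here means a smaller maximal response, a higher number a larger maximal response. Compound 1 `Cc1cccc(NC(=O)CN2CCC(c3nccs3)CC2)c1` carries a 1,3-thiazol-2-yl group on a saturated ring carbon, and in this assay compound 1 gives 62%. Compound 2 `Cc1cccc(NC(=O)CN2CCC(c3ccccc3)CC2)c1` carries a phenyl at that place, and compound 2 gives 37%. Compound 3 `Cc1cccc(NC(=O)CN2CCC(c3ccccc3C)CC2)c1` carries a 2-methylphenyl, and compound 3 gives 43%. This puts compound 3 second highest of the three; against compound 2 the difference is small, as a number 6 percentage points higher from compound 2 to compound 3 (within the scatter), whereas a number 19 percentage points lower from compound 1 to compound 3 (beyond the scatter).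

Compound 4 `Cc1cccc(NC(=O)CN2CCC(c3cccc(C#N)n3)CC2)c1` has not yet been measured. (6-cyanopyridin-2-yl in place of 2-methylphenyl on a saturated ring carbon). For the measured compounds named here, two measured steps bear on this change: replacing the 1,3-thiazol-2-yl group by a carbon-only ring lowered the response in both cases, since a number 25 percentage points lower from compound 1 to compound 2 (beyond the scatter) and a number 19 percentage points lower from compound 1 to compound 3 (beyond the scatter). Compound 4 goes the other way, from a carbon-only ring back to an aromatic ring with a hetero atom, so a modest rise is expected, a number 12 percentage points higher from compound 3 to compound 4 (beyond the scatter). Compound 4 is therefore estimated to give 55%, within a range from 35% to 75%.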

Compound 4, largest response reached (reported as efficacy), in percent of the reference or control that the assay uses: 42%
Beside the measured number, compound 4's estimate is 13 percentage points above it; the measured number falls inside the stated range.
By their numbers in this assay, from the lowest: compounds 2, 4 and 3 (each within the scatter of the next); then compound 1.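

In this assay, an aromatic ring with a hetero atom on this saturated ring carbon does not by itself restore the larger response: the swap to 6-cyanopyridin-2-yl gives a number 1 percentage points lower from compound 3 to compound 4 (within the scatter), and the comparison with the plain phenyl gives a number 5 percentage points higher from compound 2 to compound 4 (within the scatter). The 1,3-thiazol-2-yl group stays apart from all three six-membered aromatic rings, with a number 20 percentage points lower from compound 1 to compound 4 (beyond the scatter), so compound 1 keeps the highest response of the four. No measurement here explains why these groups differ or why compounds 2, 3 and 4 sit so close together.

Still open, from the compounds shown here alone, is whether the nitrile or the ring nitrogen shapes the result for compound 4, which a plain pyridin-2-yl group would help to separate. Going by these compounds, it is also open whether a 1,3-oxazol-2-yl group would match the response of compound 1.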